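Selenium to sulfur: a step without a measured floor

The compounds below may be only part of what the source reports. "The series", "measured", "known", "first", "only" and "open" are said of these compounds alone.

The measured compounds in a functional assay on MCF7 cells (Homo sapiens) for cytotoxicity, read by MTT assay, with a stated time of 72 h (a higher number here means that more compound is tolerated, a lower number that less compound is tolerated), are three. Compound 1 `COc1ccc(CNc2nc([SeH])nc3ccccc23)cc1` gives > 100000 nM, a limit of the assay. Compound 2 `CSc1ccc(CNc2nc([SeH])nc3ccccc23)cc1` gives > 100000 nM, also a limit. Compound 3 `CCCCCSc1nc(O)c2ccccc2n1` gives > 100000 nM, again a limit.

Compound 1 therefore stands nowhere exact: in this assay only a limit is known for it. The other two measured compounds give nothing more precise either. For the measured compounds named here, the one measured step between neighbours, a step that the two limits leave unreadable from compound 1 to compound 2, is unreadable; its two ends are both limits. That is the whole of the direct evidence: the limit of > 100000 nM in this assay, at which 3 of the 3 values shown sit.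

Compound 4 `COc1ccc(CNc2nc(S)nc3ccccc23)cc1` differs from compound 1 in one place: one sulfur atom in place of one selenium atom, on an aromatic carbon. Going by the values given here, no measured step covers a swap of selenium for sulfur, and the only step that exists, a step that the two limits leave unreadable from compound 1 to compound 2, concerns a different position and cannot be read itself. So no size or direction of change in this assay can be derived from the measured compounds; the expectation is simply that compound 4 also ends at the assay limit, with nothing beyond the scatter visible. Accordingly compound 4 is expected at 100000 nM, within 30000 nM to 300000 nM. The step of a number no higher from compound 1 to compound 4 (the limit leaves the size open) is thus estimated as none beyond the scatter.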

Compound 4, concentration lethal to 50% of the cells: 78400 nM
The estimate for compound 4 lay 1.3-fold (0.11 log units) above the measured number, and the stated range covers the measured number.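

Sulfanyl in place of selenium, on the aromatic carbon between two ring nitrogen atoms, produces the only exact number among the compounds shown: in this assay compound 4 gives 78400 nM, a true reading rather than a limit. On these data alone, the change itself reads as an at least 1.2-fold lower number from compound 1 to compound 4 (0.10 log units; that floor lies within the scatter), and only this floor is known, so the real size of the step stays open, and on the printed numbers it cannot be told apart from the scatter of repeated measurements. For the compounds shown here, what the result does show is that the core of compound 1, carrying sulfanyl at this position and no selenium, can give a measurable number in this assay, which no earlier compound did.

Still open, as far as these compounds go, is whether the same swap would act alike on compound 2, whose step from compound 1 cannot be read, and whether an amine or a carboxylic acid at this position would give a number further from the ceiling. For now, nearly all of the series gives no exact reading to compare against: the limit of > 100000 nM in this assay, at which 3 of the 4 values shown sit.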